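A few compounds are considered here, and "the series" means these few. Any claim that something is new, unique, unknown or untested is made for them only; others in the source may bear on it.

Measured so far:
- compound 1, `CNc1ncnc2c1ncn2Cc1ccc(F)cc1F`: 20 mg/kg
- compound 2, `CNc1ncnc2c1ncn2Cc1c(F)cccc1Cl`: 12.5 mg/kg
- compound 3, `CC(C)(C)Nc1ncnc2c1ncn2Cc1ccccc1F`: > 50 mg/kg

All three share one core and differ in the group on the aromatic carbon and in the substituents on the pendant ring. In a functional assay on the whole organism with Rattus norvegicus as the target, in the maximal electroshock model (a lower number here means that less compound is needed, a higher number that more compound is needed for the effect), compound 1 gives 20 mg/kg, and compound 2 gives 12.5 mg/kg; these two values lie within the usual scatter of each other. For compound 3 this assay gives only a limit, > 50 mg/kg, so no number is known for it; it sits at the limit of > 50 mg/kg in this assay, at which 1 of the 3 values shown sits. Nothing else is known about it.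

Compound 4, `CN(C)c1ncnc2c1ncn2Cc1ccccc1F`, has not yet been measured. It differs from compound 3 in one place: dimethylamino in place of (tert-butyl)amino on an aromatic carbon. Going by the values given here, no measured pair shows this change, so the size of the step can only be guessed. Since compound 3 stands at a limit, any number for compound 4 would count as a step downward; the expected step is an at least 1.6-fold lower number from compound 3 to compound 4 (0.22 log units; that floor lies within the scatter). Compound 4 is expected to give about 30 mg/kg in this assay, between 10 mg/kg and 90 mg/kg.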

Compound 4, dose for half-maximal effect: 8.8 mg/kg
Compound 4: middle estimate off by 3.4-fold (0.53 log units), on the high side, outside the stated range (below it).
By their numbers in this assay, from the lowest: compounds 4, 2 and 1 (each within the scatter of the next, the first and the last beyond it). At a limit, above all of these: compound 3.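

Going by these compounds alone, exchanging (tert-butyl)amino for dimethylamino on this aromatic carbon gives the first readable step at this position in this assay, with an at least 5.6-fold lower number from compound 3 to compound 4 (0.75 log units; beyond the scatter). So the group at this place can clearly shift how much compound is needed, and the true step may be larger, because compound 3 stands at a limit: the limit of > 50 mg/kg in this assay, at which 1 of the 4 values shown sits. The change removes the hydrogen-bond donor and goes from 5 heavy atoms to 3 in a single move, and this one pair cannot separate those two differences.

Open, then, is which of the two differences matters, if either does alone. A plain amino group or an ethylamino group at this place, with the pendant ring of compound 4 kept unchanged, would help to separate them, and the compounds shown do not settle this.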